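The source may hold more compounds than are shown below. What is called first, only, known or untested is meant among the compounds shown, and "the series" means these compounds.

Compound 1 `Cc1cc(Cl)c(S(C)(=O)=O)cc1C(=O)N=C(N)N` gives 25 nM in a functional assay for inhibition of sodium/hydrogen exchanger (Oryctolagus cuniculus); on this read-out lower numbers stand for stronger inhibition and higher numbers for weaker inhibition. Compound 2 `Cc1cc(-c2ccco2)c(S(C)(=O)=O)cc1C(=O)N=C(N)N` gives 16 nM in this assay. Among the measured compounds shown here, the single measured step, a 1.6-fold lower number from compound 1 to compound 2 (0.19 log units; within the scatter), is within the scatter, so compound 2 and compound 1 stand at numbers that cannot be told apart on this read-out, and neither can be called the stronger inhibitor on the basis of the two values.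

Compound 3 `Cc1cc(SC(C)(C)C)c(S(C)(=O)=O)cc1C(=O)N=C(N)N` has not yet been measured. It differs from compound 2 in one place: (tert-butyl)sulfanyl in place of furan-2-yl on an aromatic carbon. For the measured compounds named here, the only measured step that bears on this change is the one at the same aromatic carbon, a 1.6-fold lower number from compound 1 to compound 2 (0.19 log units; within the scatter), which replaced chloro by furan-2-yl and stayed within the scatter. Going by the values given here, no measured step involves a (tert-butyl)sulfanyl group, so there is no direct evidence for this particular group at that position.

Given that the one exchange at this carbon produced no change beyond the scatter, the step to compound 3 is expected to be small as well, a 1.3-fold higher number from compound 2 to compound 3 (0.10 log units; within the scatter). Compound 3 is therefore estimated at 20 nM in this assay, with a range from 6 nM to 65 nM.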

Compound 3, half-maximal inhibitory concentration: 22 nM
For compound 3 the middle estimate is 1.1-fold (0.04 log units) below the measured one; measured number inside the range.
By their numbers in this assay, from the lowest: compounds 2, 3 and 1 (each within the scatter of the next).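

The exchange of furan-2-yl for (tert-butyl)sulfanyl on this aromatic carbon gives a 1.4-fold higher number from compound 2 to compound 3 (0.14 log units; within the scatter) in this assay, and the exchange of chloro for (tert-butyl)sulfanyl gives a 1.1-fold lower number from compound 1 to compound 3 (0.06 log units; within the scatter) on the same read-out. The earlier pair had shown only that a chloro and a furan-2-yl could not be told apart here, whereas compound 3 adds a group with no ring, joined through sulfur, and its number still cannot be told apart from either of the others, so among these three compounds a five-membered aromatic ring at this carbon is not needed to keep the number where it stands. Nothing measured here speaks to what lies behind this sameness across the three groups.

The three groups leave open whether the number would stay the same with an amine, a carboxylic acid or a longer alkyl chain on this carbon, since none of these appears among the compounds shown. It is also open whether a step beyond the scatter can be found at this carbon at all, as every exchange shown so far lies within it.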